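This account rests on a few compounds, and the source may have more. Where it says the series, first, only, none or still open, it means among the compounds named here.

Measured so far:
compound 1, `O=C(N/N=C/c1ccccc1)c1cccnc1Nc1cccc(C(F)(F)F)c1` — 60.4%
compound 2, `O=C(N/N=C/c1ccc(O)cc1)c1cccnc1Nc1cccc(C(F)(F)F)c1` — 59.3%

In a functional assay on the whole organism (strain Wistar) for inhibition, with Rattus norvegicus as the target, read by paw edema, with a stated time of 30 min, at a dose of 10 mg/kg by the intraperitoneal route (a lower number here means less inhibition, a higher number more inhibition at the dose given (going by the name of the read-out)), compound 1 gives 60.4% and compound 2 gives 59.3%. For the measured compounds named here, the one measured step, a number 1.1 percentage points lower from compound 1 to compound 2 (within the scatter), is within the scatter, so compound 2 stands level with compound 1, the only other number recorded, and neither number can be called the higher of the two.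

Compound 3, `COc1cccc(/C=N/NC(=O)c2cccnc2Nc2cccc(C(F)(F)F)c2)c1`, is the next compound. Its difference from compound 2 is 3-methoxyphenyl in place of 4-hydroxyphenyl on a carbon with a double bond to nitrogen. The measured step bears on this only in part: it shows that adding a hydroxy to the ring gave a number 1.1 percentage points lower from compound 1 to compound 2 (within the scatter), a change within the scatter, while nothing measured shows what a methoxy on this ring does, nor what a shift of the substituent to the position named above does. Going by the values given here, with the one relevant step being flat, the expected step of a number 1.3 percentage points lower from compound 2 to compound 3 (within the scatter) is small and not beyond the scatter. Compound 3 is therefore estimated at 58%, with a range from 46% to 68%.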

Compound 3, a percentage reported as inhibition, in the whole organism at one dose (the size of the read-out at that dose, not a potency): 52.8%
Compound 3: middle estimate off by 5.2 percentage points, on the high side; low and high end bracket the measured number.
By their numbers in this assay, from the lowest: compounds 3, 2 and 1 (each within the scatter of the next).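

In this assay, this result brings in a methoxy on the ring held by the carbon with a double bond to nitrogen, a group the earlier pair did not include, and the step of a number 7.6 percentage points lower from compound 1 to compound 3 (within the scatter) leaves 3-methoxyphenyl not distinguishable from the plain phenyl ring at this dose. The exchange of 4-hydroxyphenyl for 3-methoxyphenyl, which takes the count of hydrogen-bond donors on this group from 1 to 0, gives a number 6.5 percentage points lower from compound 2 to compound 3 (within the scatter), so this larger change of group does not separate the two compounds either, and across all three compounds this position has not yet produced a difference beyond the scatter. Nothing available explains these numbers or links them to any measured property of the groups.

The step from 4-hydroxyphenyl to 3-methoxyphenyl changes both the group and its place on the ring, and no compound shown separates those two changes. From the compounds shown here alone, what an amine, a carboxylic acid or a longer alkoxy chain would do on this ring stays open, as does whether any change to the trifluoromethyl group or the shared core would move the inhibition of paw edema beyond the scatter.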